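The source may report more compounds than this note shows. Statements on the series, on what has been measured and on what is new or still open speak of the compounds shown alone.

In an in vitro ADME assay on microsomes from liver (Homo sapiens) for pharmacokinetics, read by LC-MS, with a stated time of 10 min, tested at 1 uM (on this read-out higher numbers stand for fast clearance and lower numbers for slow clearance), three compounds sharing one core have been measured: compound 1 `COc1ccc(NC(=O)[C@H]2CN(C)C[C@@H]2c2ccc(/C=C/C(=O)Nc3ccccc3N)cc2)cc1` gives 14 mL/min/kg, compound 2 `CC(C)c1ccc(NC(=O)[C@H]2CN(C)C[C@@H]2c2ccc(/C=C/C(=O)Nc3ccccc3N)cc2)cc1` gives 10 mL/min/kg and compound 3 `CN1C[C@H](C(=O)Nc2ccc(C3CC3)cc2)[C@@H](c2ccc(/C=C/C(=O)Nc3ccccc3N)cc2)C1` gives 12 mL/min/kg. These three numbers lie within the scatter of one another, so compound 3 is not set apart from the other two. The next structure, compound 4 `CN1C[C@H](C(=O)Nc2ccc(C(F)(F)F)cc2)[C@@H](c2ccc(/C=C/C(=O)Nc3ccccc3N)cc2)C1`, keeps the core and has trifluoromethyl in place of cyclopropyl on an aromatic carbon. Three measured steps changed the group at this same place: a 1.4-fold lower number from compound 1 to compound 2 (0.15 log units; within the scatter), a 1.2-fold lower number from compound 1 to compound 3 (0.07 log units; within the scatter) and a 1.2-fold higher number from compound 2 to compound 3 (0.08 log units; within the scatter). All three stayed within the scatter. Among the compounds with values here, none of the measured compounds carries trifluoromethyl, so the data do not rule out a larger move, and the range given here is kept wide. In this assay, no step beyond the scatter is expected, and the estimated step is no change at the digits printed from compound 3 to compound 4 (within the scatter). For compound 4 the estimated clearance is 12 mL/min/kg, expected to fall between 7 mL/min/kg and 22 mL/min/kg.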

Compound 4, clearance: 6 mL/min/kg
For compound 4 the middle estimate is 2.0-fold (0.30 log units) above the measured one; the measured number lies below the stated range.
By their numbers in this assay, from the lowest: compounds 4, 2, 3 and 1 (each within the scatter of the next, the first and the last beyond it).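

In this assay this position on the aromatic ring now gives its first step beyond the scatter, a modest one: trifluoromethyl in place of methoxy brings a 2.3-fold lower number from compound 1 to compound 4 (0.37 log units; beyond the scatter) at this place. Trifluoromethyl is not set apart from the two carbon groups, since replacing cyclopropyl gives a 2.0-fold lower number from compound 3 to compound 4 (0.30 log units; within the scatter) and replacing isopropyl gives a 1.7-fold lower number from compound 2 to compound 4 (0.22 log units; within the scatter) in this series. No measurement at hand explains the step from methoxy.

The compounds shown leave open how a group of another kind at this place, such as an amine, a carboxylic acid or a longer chain, would compare with trifluoromethyl. They also leave open whether the step from methoxy to trifluoromethyl would be seen again on a different core.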